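Compound 2 to compound 4: rearranging the carbonyl-linked group

The compounds below may be only part of what the source reports. "The series", "measured", "known", "first", "only" and "open" are said of these compounds alone.

Values in a functional assay on MDA-MB-231 cells (Homo sapiens) for cytotoxicity, read by MTT assay, with a stated time of 72 h; a higher number here means a weaker inhibitor, a lower number a stronger inhibitor:
- compound 1 `Nc1ccccc1NC(=O)c1ccc(CNC(=O)c2cc3cccnc3[nH]2)cc1`: > 100000 nM (a limit of the assay)
- compound 2 `Nc1ccccc1NC(=O)c1ccc(CNC(=O)c2cc3cnccc3[nH]2)cc1`: 48000 nM
- compound 3 `Nc1ccccc1NC(=O)c1ccc(NC(=O)NCc2cccnc2)cc1`: > 100000 nM (a limit of the assay)

Going by the values given here, compound 2 gives the only actual number in this assay, 48000 nM. The other two results stand at the limit of > 100000 nM in this assay, at which 2 of the 3 values shown sit.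

Compound 4 `Nc1ccccc1NC(=O)c1ccc(CNC(=O)c2ccc3cncn3c2)cc1` is still to be measured. It has the same atoms as compound 2, joined differently: a group of 9 heavy atoms (7 carbon, 2 nitrogen; one five-membered aromatic ring with 2 hetero atoms, one six-membered aromatic ring with 1 hetero atom) in place of a group of 9 heavy atoms (7 carbon, 2 nitrogen; one five-membered aromatic ring with 1 hetero atom, one six-membered aromatic ring with 1 hetero atom), on a carbonyl carbon. The change sits on a carbonyl carbon whose other neighbour is an amide-type nitrogen.

Among the compounds with values here, one measured step bears on this, an at least 2.0-fold lower number from compound 1 to compound 2 (0.31 log units; beyond the scatter). It is also an exchange of groups of equal atom count at this carbonyl carbon, and it is modest, with a limit at one end. Within the data shown here, no measured step covers the group that enters in compound 4, so the direction is only a weak call. Of the compounds with this kind of group, only compound 2 gave a number, so a drift towards the limit is more likely than a gain.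

Among the measured compounds shown here, the expected change, with an at least 2.0-fold lower number from compound 1 to compound 2 (0.31 log units; beyond the scatter) as the only guide, is a 1.3-fold higher number from compound 2 to compound 4 (0.10 log units; within the scatter), so no estimated shift beyond the scatter. For compound 4 the estimated value is 60000 nM, with an expected range of 25000 nM to 100000 nM.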

Compound 4, half-maximal inhibitory concentration: 54000 nM
Estimate against measurement, compound 4: 1.1-fold (0.05 log units) above; low and high end bracket the measured number.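

In this assay, a group with 0 hydrogen-bond donors and 2 hydrogen-bond acceptors replaces one with 1 of each on the carbonyl carbon, and the result is a 1.1-fold higher number from compound 2 to compound 4 (0.05 log units; within the scatter). So compound 4 shows that a measurable value at this position does not depend on the hydrogen-bond donor of compound 2, and that moving a hetero atom into the five-membered ring need not shift the number beyond the scatter, as the earlier compounds could not show. The other step, an at least 1.8-fold lower number from compound 1 to compound 4 (0.26 log units; that floor lies within the scatter), rests on the limit of compound 1, so it does not show that compound 4 separates from compound 1, and the contrast seen so far among these equal-sized groups remains the one step to compound 2.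

As far as these compounds go, the readable range of this series remains narrow, with the two measured numbers sitting within the scatter of each other and the other results at a limit: the limit of > 100000 nM in this assay, at which 2 of the 4 values shown sit. Still open is whether an amine or a carboxylic acid on the carbonyl-linked group, or a single pyridine ring in place of the two-ring groups, would move the value beyond the scatter of compound 2.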